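Chain-branching on the enamide of the shared core

The source may hold more compounds than are shown below. What is called first, only, known or untested is meant among the compounds shown, and "the series" means these compounds.

Measured compounds, read in a functional assay on A549 cells (Homo sapiens) for inhibition, read by MTT assay, with a stated time of 72 h; a lower number here means a stronger inhibitor, a higher number a weaker inhibitor:
compound 1 `C/C=C/C(=O)Nc1cccc(Oc2nc(Nc3cccc(C#N)c3)nc3ccsc23)c1` gives 11300 nM
compound 2 `CC(C)=CC(=O)Nc1cccc(Oc2nc(Nc3cccc(C#N)c3)nc3ccsc23)c1` gives 16900 nM
compound 3 `CC/C=C/C(=O)Nc1cccc(Oc2nc(Nc3cccc(C#N)c3)nc3ccsc23)c1` gives 14900 nM

All three share one core and differ only in the unsaturated chain on the carbonyl carbon of the amide. In this assay compound 3 sits between the other two numbers; its nearest neighbour is compound 2 a 1.1-fold lower number from compound 2 to compound 3 (0.05 log units; within the scatter) and its furthest is compound 1 a 1.3-fold higher number from compound 1 to compound 3 (0.12 log units; within the scatter), so nothing in the set separates beyond the scatter. The remaining pair, a 1.5-fold higher number from compound 1 to compound 2 (0.17 log units; within the scatter), is likewise within the scatter.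

Compound 4 `CC(C)/C=C/C(=O)Nc1cccc(Oc2nc(Nc3cccc(C#N)c3)nc3ccsc23)c1` is not yet measured. It differs from compound 3 by methyl in place of hydrogen on a saturated chain carbon bound to a double-bonded chain carbon and a saturated chain carbon. Going by the values given here, the closest precedent is the addition of a methyl on a saturated chain carbon in going from compound 1 to compound 3, which gave a 1.3-fold higher number from compound 1 to compound 3 (0.12 log units; within the scatter); the other two steps, both also variations of the same chain, stayed flat as well. Among the compounds with values here, no measured step therefore points to a change in this assay beyond the scatter, in either direction.

Compound 4 is accordingly expected to give about 15000 nM, with a range of 7000 nM to 33000 nM, the step of a 1.0-fold higher number from compound 3 to compound 4 (0.00 log units; within the scatter) being an estimate of essentially no movement.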

Compound 4, half-maximal inhibitory concentration: 19000 nM
The estimate for compound 4 lay 1.3-fold (0.10 log units) below the measured number; measured number inside the range.
By their numbers in this assay, from the lowest: compounds 1, 3, 2 and 4 (each within the scatter of the next).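

Working from the chain on the carbonyl carbon, methyl in place of hydrogen on the saturated chain carbon, which turns ethyl into isopropyl, leaves the reading in this assay flat (a 1.3-fold higher number from compound 3 to compound 4 (0.11 log units; within the scatter)), so a branch at this carbon, a change not covered by compounds 1 to 3, separates nothing from the unbranched chain. The comparison with the other branched chain, 3-methylbut-1-en-1-yl in place of 2-methylprop-1-en-1-yl, is equally flat (a 1.1-fold higher number from compound 2 to compound 4 (0.05 log units; within the scatter)), and even isopropyl in place of methyl on the double-bonded chain carbon, the largest of the changes among these four chains, stays inside the scatter (a 1.7-fold higher number from compound 1 to compound 4 (0.23 log units; within the scatter)). All four compounds therefore read alike in this assay, and nothing available accounts for that flatness.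

The compounds shown leave open whether any group at this chain end can move the number beyond the scatter, for instance a dimethylamine, a carboxylic acid or a phenyl ring. They also leave open what a saturated propyl chain in place of the double-bonded chain, or an unsubstituted vinyl group on the carbonyl carbon, would read.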